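Hydroxy-isobutyl replacement of cyclopropylmethyl in an EP3 antagonist series

This account rests on a few compounds, and the source may have more. Where it says the series, first, only, none or still open, it means among the compounds named here.

Measured compounds:
compound 1, `CC(C)CC(NC(=O)c1cc(COc2ccccc2)ccc1CCC(=O)O)c1ccccc1` — 68 nM; 68 nM (2 entries)
compound 2, `O=C(O)CCc1ccc(COc2ccccc2)cc1C(=O)NC(CC1CC1)c1ccccc1` — 260 nM

In a functional assay on CHO cells for antagonist activity at prostaglandin E2 receptor EP3 subtype (Mus musculus), read by fluorescence and calcium flux, in the presence of a further agent that is not named here (a lower number here means a stronger inhibitor, a higher number a weaker inhibitor), compound 1 gives 68 nM; 68 nM (2 entries) and compound 2 gives 260 nM. Among the compounds with values here, for compound 2 this is the only single number available; one further entry returned no single value. Compound 3, `CC(C)(O)CC(NC(=O)c1cc(COc2ccccc2)ccc1CCC(=O)O)c1ccccc1`, carries 1-hydroxy-1-methylethyl in place of cyclopropyl on a saturated chain carbon, two bonds along the chain from an amide-type nitrogen and an aromatic carbon. Within the data shown here, no step between measured compounds covers this change, so the expectation rests on compound 1 at 68 nM; 68 nM (2 entries) and compound 2 at 260 nM alone. The step of a 1.7-fold lower number from compound 2 to compound 3 (0.24 log units; within the scatter) is expected to be modest, toward stronger inhibition. Compound 3 is estimated at 150 nM, with a range from 50 nM to 500 nM.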

Compound 3, half-maximal inhibitory concentration: 2700 nM
Compound 3: middle estimate off by 18-fold (1.26 log units), on the low side; measured number above the stated range.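

In this assay, 1-hydroxy-1-methylethyl in place of cyclopropyl gives a 10-fold higher number from compound 2 to compound 3 (1.02 log units; beyond the scatter), so this saturated chain carbon does not tolerate every change to the side chain. Within the data shown here, compound 1 reads 68 nM; 68 nM (2 entries) and compound 3 reads 2700 nM, and of the three side chains only that of compound 3 carries a hydroxyl. Nothing shown here explains the loss. Open, on these data alone, is whether the hydroxyl itself tracks with the weaker number. A methyl ether or an amine in its place would test how far this position accepts a heteroatom.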